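The compounds below may be only part of what the source reports. "The series", "measured", "known", "first", "only" and "open" are said of these compounds alone.

Compound 2 `COc1cc(N)c(Cl)cc1NC(=O)C1CCN(CC2CCCCCC2)CC1` stands only at a limit in a functional assay on the whole organism for antagonist activity, with Mus musculus as the target; on this read-out higher numbers stand for an effect only at larger amounts of compound and lower numbers for an effect already at smaller amounts: compound 2 gives > 10 mg/kg, which is a limit of the assay and not a measured number. The change from compound 2 to compound 3 `COc1cc(N)c(Cl)cc1NC(=O)C1CCN(Cc2cccc(Cl)c2)CC1` is 3-chlorophenyl in place of cycloheptyl on a saturated chain carbon bound to an amine nitrogen in a ring. For the measured compounds named here, the one measured step that touches this position is a step that the two limits leave unreadable from compound 1 to compound 2, and its size cannot be read, since compound 1 `COc1cc(N)c(Cl)cc1NC(=O)C1CCN(Cc2ccccc2Cl)CC1` also sits at a limit. In this assay compound 1 gives > 4 mg/kg, again a limit. Both anchors are limits, the limit of > 10 mg/kg in this assay, at which 1 of the 2 values shown sits, and (the limit of > 4 mg/kg in this assay, at which 1 of the 2 values shown sits), so neither a direction nor a size beyond the scatter can be drawn from them for the new compound. Compound 3 is accordingly expected to show a step of a number no higher from compound 2 to compound 3 (the limit leaves the size open), most probably ending once more at a limit. The estimate for compound 3 in this assay is 10 mg/kg, with a range from 3 mg/kg to 30 mg/kg.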

Compound 3, dose for half-maximal effect: > 4 mg/kg
Compound 3: a limit, no number; the forecaster's own chance of this, stated with the estimate: 75%; the middle value lies beyond the limit too.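

No new step can be read in this assay, since compound 1, compound 2 and compound 3 all stand at limits of the assay and not at numbers. The compounds shown leave open whether 2-chlorophenyl, 3-chlorophenyl and cycloheptyl differ at all on this read-out.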